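The source may hold more compounds than are shown below. What is called first, only, known or untested is meant among the compounds shown, and "the series" means these compounds.

Measured in a functional assay on PC-3 cells (Homo sapiens) for antiproliferative activity, read by MTT assay, with a stated time of 48 h; on this read-out lower numbers stand for stronger inhibition and higher numbers for weaker inhibition:
- compound 1 `Brc1ccc(-c2nnc(-c3cn4ccccc4n3)o2)cc1`: > 50000 nM (a limit of the assay, not a number)
- compound 2 `Cc1cccn2cc(-c3nnc(-c4ccccc4)o3)nc12`: 22800 nM
- compound 3 `Cc1cccn2cc(-c3nnc(-c4ccc(Br)cc4)o3)nc12`: 37800 nM

In this assay compound 3 gives 37800 nM, within the usual scatter of compound 2 at 22800 nM. Both numbers point to weak inhibition of cell growth. The next compound to be measured is compound 4 `Cc1cccn2cc(-c3nnc(-c4ccc(N(C)C)cc4)o3)nc12`, which has dimethylamino in place of bromo on an aromatic carbon. The change sits on a six-membered aromatic ring of carbon only, para to a large group.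

Going by the values given here, two measured steps bear on this. At the same place, bromo in place of hydrogen gave a 1.7-fold higher number from compound 2 to compound 3 (0.22 log units; within the scatter). Elsewhere in the molecule, methyl in place of hydrogen gave an at least 1.3-fold lower number from compound 1 to compound 3 (0.12 log units; that floor lies within the scatter). Neither step stands out from the scatter, so this series has so far responded little to small changes. Among the compounds with values here, no measured compound carries dimethylamino, which leaves the expectation loose. The expected change in this assay is a 1.5-fold lower number from compound 3 to compound 4 (0.18 log units; within the scatter), with no step beyond the scatter and no firm direction. For compound 4 the estimated value is 25000 nM, with an expected range from 8000 nM to 50000 nM.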

Compound 4, half-maximal inhibitory concentration: 11600 nM
Estimate against measurement, compound 4: 2.2-fold (0.33 log units) above, and the stated range covers the measured number.
By their numbers in this assay, from the lowest: compounds 4, 2 and 3 (each within the scatter of the next, the first and the last beyond it). At a limit, above all of these: compound 1.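

In this assay, this position on the carbon-only aromatic ring, para to a large group, gives the only step shown that lies beyond the scatter: dimethylamino in place of bromo gives a 3.3-fold lower number from compound 3 to compound 4 (0.51 log units; beyond the scatter). Set against plain hydrogen at the same place, dimethylamino gives a 2.0-fold lower number from compound 2 to compound 4 (0.29 log units; within the scatter), so the position is seen to respond clearly only in the contrast between dimethylamino and bromo, not yet against the unsubstituted ring. Compound 1, for its part, stands at a limit of the assay and not at a number: the limit of > 50000 nM in this assay, at which 1 of the 4 values shown sits.

With only hydrogen, bromo and dimethylamino at this position, nothing yet separates what the nitrogen contributes from what its two added carbons contribute, and a plain amine or a diethylamino group would help to pull those apart. As far as these compounds go, it also remains open whether a carboxylic acid or a longer chain ending in an amine at the same place would carry the numbers in this assay further down, or whether the series stays in the same weak range.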